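From piperidin-1-yl to a 4-methylpiperazin-1-yl side chain

A few compounds are considered here, and "the series" means these few. Any claim that something is new, unique, unknown or untested is made for them only; others in the source may bear on it.

Measured in a functional assay on MDA-MB-231 cells (Homo sapiens) for cytotoxicity, read by MTT assay, with a stated time of 72 h (a lower number here means a stronger inhibitor, a higher number a weaker inhibitor), so far:
- compound 1 `O=C1c2c[n+]([O-])c3ccccc3c2C(=O)c2c1c1ccccc1n2Cc1cn(C[C@H](O)CO)nn1` gives 1310 nM
- compound 2 `O=C1c2c[n+]([O-])c3ccccc3c2C(=O)c2c1c1ccccc1n2CCCCN1CCCCC1` gives 610 nM

Of these two, compound 2 at 610 nM holds the lower number and is the stronger inhibitor, and its gap to compound 1 lies beyond the scatter. Compound 3 `CN1CCN(CCCCCCn2c3c(c4ccccc42)C(=O)c2c[n+]([O-])c4ccccc4c2C3=O)CC1` keeps the shared core and differs from compound 2 at the end of the side chain (2-(4-methylpiperazin-1-yl)ethyl in place of piperidin-1-yl on a saturated chain carbon, four bonds along the chain from an aromatic nitrogen), with 2-(4-methylpiperazin-1-yl)ethyl in place of piperidin-1-yl on a saturated chain carbon, four bonds along the chain from an aromatic nitrogen. Among the compounds with values here, only one measured step bears on this change, and it does so indirectly: a 2.1-fold lower number from compound 1 to compound 2 (0.33 log units; beyond the scatter) is a modest move, even though it exchanged a different group at the same side chain. Within the data shown here, no measured pair shows the present exchange itself, so the evidence is thin. On that basis the step is expected to stay small, and the estimate is a 1.1-fold lower number from compound 2 to compound 3 (0.04 log units; within the scatter) with no clear direction expected beyond the scatter. In this assay compound 3 is therefore expected at 550 nM with an estimated range (200 nM to 1500 nM).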

Compound 3, half-maximal inhibitory concentration: 2400 nM
Estimate against measurement, compound 3: 4.4-fold (0.64 log units) below; measured number outside the range, above it.
By their numbers in this assay, from the lowest: compound 2; then compounds 1 and 3 (each within the scatter of the next).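

In this assay, within the data shown here, the exchange of piperidin-1-yl for 2-(4-methylpiperazin-1-yl)ethyl, on a saturated chain carbon, four bonds along the chain from an aromatic nitrogen, gives the first direct reading of this change, and the side chain end proves sensitive (a 3.9-fold higher number from compound 2 to compound 3 (0.59 log units; beyond the scatter)). A six-membered non-aromatic ring at the end of the chain therefore does not by itself carry the number of compound 2, which remains the strongest inhibitor of the three, while compound 3 cannot be told apart from the triazole-bearing compound 1 (a 1.8-fold higher number from compound 1 to compound 3 (0.26 log units; within the scatter)). Nothing measured here accounts for the loss seen in this exchange.

The step joins two changes, the added ethyl length and the ring with its second nitrogen and methyl, and the compounds shown do not separate them: a 4-methylpiperazin-1-yl ring on the chain of compound 2, or a piperidin-1-yl ring on the chain of compound 3, would do so. Also open, going by these compounds, is how a morpholine ring or a simple dimethylamino end would read at this place.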